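Swapping methoxy for chloro on the phenylpiperazine ring

The source may hold more compounds than are shown below. What is called first, only, known or untested is meant among the compounds shown, and "the series" means these compounds.

Of the compounds shown here, three sharing one core have been measured in a functional assay on MCF7 cells (Homo sapiens) for cytotoxicity, read by sulforhodamine B assay, with a stated time of 48 h; a lower number here means a stronger inhibitor, a higher number a weaker inhibitor. Compound 1 `Clc1ccc(-c2csc3ncnc(N4CCN(c5ccc(Cl)cc5)CC4)c23)cc1` gives 42.6 nM, compound 2 `O=[N+]([O-])c1ccc(-c2csc3ncnc(N4CCN(c5ccccc5)CC4)c23)cc1` gives 28.7 nM, and compound 3 `COc1ccc(N2CCN(c3ncnc4scc(-c5ccc([N+](=O)[O-])cc5)c34)CC2)cc1` gives 36.9 nM. Compound 3 stands second highest of the three, with compound 1 nearest and compound 2 furthest, and both gaps lie within the scatter. Among the compounds with values here, the single measured step to compound 3, a 1.3-fold higher number from compound 2 to compound 3 (0.11 log units; within the scatter), was methoxy in place of hydrogen on an aromatic carbon and did not move the number beyond the scatter.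

Compound 4 `O=[N+]([O-])c1ccc(-c2csc3ncnc(N4CCN(c5ccc(Cl)cc5)CC4)c23)cc1` differs from compound 3 by chloro in place of methoxy on an aromatic carbon. Within the data shown here, no measured step exchanges chloro for methoxy directly; compound 1 merely shows that a chloro on that ring sits with a number in the same region as the others. Among the measured compounds shown here, since the only step on this ring stayed within the scatter, compound 4 is expected to show a 1.1-fold lower number from compound 3 to compound 4 (0.02 log units; within the scatter), no change beyond the scatter. Compound 4 is therefore estimated at 35 nM, between 17 nM and 70 nM.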

Compound 4, half-maximal inhibitory concentration: 54.4 nM
Compound 4: the middle estimate sits 1.6-fold (0.19 log units) below what was measured, and the stated range covers the measured number.
By their numbers in this assay, from the lowest: compounds 2, 3, 1 and 4 (each within the scatter of the next).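

At this place, the step of a 1.5-fold higher number from compound 3 to compound 4 (0.17 log units; within the scatter) in this assay and the step of a 1.9-fold higher number from compound 2 to compound 4 (0.28 log units; within the scatter) in the same assay show that, with nitro held constant elsewhere, hydrogen, methoxy and chloro have all now been compared directly, and no exchange among them leaves the scatter. Within the data shown here, the step of a 1.3-fold higher number from compound 1 to compound 4 (0.11 log units; within the scatter) adds a first direct reading of nitro in place of chloro on the other aromatic ring, with chloro held on this one, and it too stays within the scatter. Nothing available bears on why these numbers fall as they do.

The compounds shown leave open whether an amine or a carboxylic acid on this ring, or a longer chain in place of methoxy, would also stay within the scatter. They also leave open whether methoxy and chloro would compare the same way with a group other than nitro or chloro on the other aromatic ring.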